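Replacing the Nitrophenyl Group on the Shared Core

A few compounds are considered here, and "the series" means these few. Any claim that something is new, unique, unknown or untested is made for them only; others in the source may bear on it.

Three compounds sharing one core have been examined in a functional assay on Ehrlich cells (Mus musculus) for cytotoxicity, read by trypan blue exclusion, with a stated time of 2 h, tested at 10 ug/mL; on this read-out lower numbers stand for a weaker effect and higher numbers for a stronger effect at the one concentration tested. Compound 1 `Cc1ccc(C2C(C#N)=C(N)N(c3ccc(S(N)(=O)=O)cc3)C3=C2CCCC3)cc1` gives 20%, compound 2 `N#CC1=C(N)N(c2ccc(S(N)(=O)=O)cc2)C2=C(CCCC2)C1/C=C/c1ccccc1` gives 50%, and compound 3 `N#CC1=C(N)N(c2ccc(S(N)(=O)=O)cc2)C2=C(CCCC2)C1c1cccc([N+](=O)[O-])c1` gives 0%, the lowest of the three numbers. The steps that reach compound 3 both fall: a number 20 percentage points lower from compound 1 to compound 3 (beyond the scatter) and a number 50 percentage points lower from compound 2 to compound 3 (beyond the scatter), while a number 30 percentage points higher from compound 1 to compound 2 (beyond the scatter) shows the styrene-bearing compound standing highest. Compound 4 `N#CC1=C(N)N(c2ccc(S(N)(=O)=O)cc2)C2=C(CCCC2)C1c1c(O)ccc2ccccc12` has not yet been measured; it differs from compound 3 by 2-hydroxynaphthalen-1-yl in place of 3-nitrophenyl on a saturated ring carbon. Within the data shown here, no measured step involves a 2-hydroxynaphthalen-1-yl group, so none bears directly on this change; what the steps show is that the 3-nitrophenyl compound sits at the floor and that the other two groups tried in this place lie above it. Compound 4 is therefore expected to rise from that floor by about a number 25 percentage points higher from compound 3 to compound 4 (beyond the scatter) in this assay. Compound 4 is estimated at 25%, with a plausible range from 5% to 55%.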

Compound 4, a percentage reported as activity, at one concentration (the size of the read-out at that concentration, not a potency): 10%
For compound 4 the middle estimate is 15 percentage points above the measured one; the range from low to high includes it.
By their numbers in this assay, from the lowest: compounds 3, 4 and 1 (each within the scatter of the next, the first and the last beyond it); then compound 2.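

In this assay the 2-hydroxynaphthalen-1-yl group, with its two six-membered aromatic rings of carbon only and its hydrogen-bond donor, cannot be told apart from the 3-nitrophenyl group (a number 10 percentage points higher from compound 3 to compound 4 (within the scatter)) or from the 4-methylphenyl group (a number 10 percentage points lower from compound 1 to compound 4 (within the scatter)). The 2-phenylethenyl group stays clearly separate from it (a number 40 percentage points lower from compound 2 to compound 4 (beyond the scatter)), so at this saturated ring carbon compound 2 now stands apart from three compounds that carry an aromatic ring directly on that carbon, although compound 1 and compound 3 differ beyond the scatter. Nothing available explains this separation.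

The compounds shown leave open whether the hydroxyl group or the second aromatic ring of the naphthalene matters, which a plain naphthalen-1-yl or 2-hydroxyphenyl group would address. They also leave open whether the ethenyl link itself matters, which a 2-phenylethyl chain at this carbon would test.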